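Working notes: methyl to bromo on compound 1

The source may hold more compounds than are shown below. What is called first, only, known or untested is meant among the compounds shown, and "the series" means these compounds.

Measured in a functional assay on MCF7 cells (Homo sapiens) for antiproliferative activity, read by MTT assay, with a stated time of 72 h; a lower number here means a stronger inhibitor, a higher number a weaker inhibitor:
- compound 1 `COc1ccc(/C=C2/CN(C)/C(=N/c3ccc(C)cc3)S2)cc1` gives 7600 nM
- compound 2 `C=C1CN(C)/C(=N/c2ccccc2)S1` gives > 100000 nM, which is a limit of the assay
- compound 3 `COc1ccc(/C=C2\S/C(=N\c3ccc(C)c(Cl)c3)N(C)C2=O)cc1` gives > 100000 nM, which is a limit of the assay

Among the measured compounds shown here, compound 1 is the only compound in this set with a measured number. Compound 2 and compound 3 stand at the limit of > 100000 nM in this assay, at which 2 of the 3 values shown sit. For the measured compounds named here, no measured pair differs in one place only, so the set offers no direct guide to the size of a single change.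

Compound 4 `COc1ccc(/C=C2/CN(C)/C(=N/c3ccc(Br)cc3)S2)cc1` differs from compound 1 at one site: bromo in place of methyl on an aromatic carbon. This is bromo in place of methyl on an aromatic carbon, turning 4-methylphenyl into 4-bromophenyl, with the rest of the structure unchanged.

Going by the values given here, with no measured step to draw on, no shift beyond the usual scatter is expected in this assay, and neither direction is clearly favoured. The starting point for this expectation is compound 1 at 7600 nM. The expected change, a 1.2-fold lower number from compound 1 to compound 4 (0.07 log units; within the scatter), is therefore small. For compound 4 the estimated value is 6500 nM, with an expected range of 2000 nM to 22000 nM.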

Compound 4, half-maximal inhibitory concentration: 7400 nM
Beside the measured number, compound 4's estimate is 1.1-fold (0.06 log units) below it, and the stated range covers the measured number.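

In this assay, among the compounds shown here, bromo in place of methyl on the aromatic carbon gives a 1.0-fold lower number from compound 1 to compound 4 (0.01 log units; within the scatter), the only single-place step that can be read in this set. Turning 4-methylphenyl into 4-bromophenyl therefore leaves the read-out within the scatter, so the measured activity of this series does not depend on the methyl group specifically, and this position accepts at least one other substituent of a single heavy atom, with compound 4 at 7400 nM. Nothing among the compounds shown gives a cause for this result, and a shared value does not establish that methyl and bromo act in the same way.

One step at one position leaves open how far this tolerance extends, since a dimethylamino group, a carboxylic acid or a longer chain such as n-butyl on the same aromatic carbon could behave quite differently. As far as these compounds go, it also remains open whether the same tolerance would hold with the rest of the core of compound 1 changed, or whether any group at this position can move the number beyond the scatter.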